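Replacing pyridin-3-yl with butyl: a step into the unknown

A few compounds are considered here, and "the series" means these few. Any claim that something is new, unique, unknown or untested is made for them only; others in the source may bear on it.

Compound 1 `O=C1COc2ccccc2N1CCCn1cc(-c2ccccc2)nn1`: 370 nM
Compound 2 `Cc1ccc(-c2cn(CCCN3C(=O)COc4ccccc43)nn2)cc1`: 4400 nM
Compound 3 `O=C1COc2ccccc2N1CCCn1cc(-c2cccnc2)nn1`: 860 nM

These three compounds share one core and differ only in the ring group it carries. In a functional assay on IMR-32 cells (Homo sapiens) for antiproliferative activity, read by sulforhodamine B assay, with a stated time of 48 h (on this read-out higher numbers stand for weaker inhibition of growth and lower numbers for stronger inhibition of growth), compound 3 gives 860 nM, the second highest of the three numbers, which places it in the middle of the series. The measurements show a 2.3-fold higher number from compound 1 to compound 3 (0.37 log units; beyond the scatter) and a 5.1-fold lower number from compound 2 to compound 3 (0.71 log units; beyond the scatter).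

Compound 4 `CCCCc1cn(CCCN2C(=O)COc3ccccc32)nn1` has not yet been measured. The change is butyl in place of pyridin-3-yl on an aromatic carbon; in words, butyl in place of pyridin-3-yl on an aromatic carbon. Among the compounds with values here, no measured compound carries an open chain at this place, so the known steps offer only indirect guidance. All of them exchange one aromatic ring group for another. Even so, they show how far a small edit can move the number. Since a 12-fold higher number from compound 1 to compound 2 (1.08 log units; beyond the scatter) came from adding only a methyl, a modest step towards a higher number is expected in this assay, with wide uncertainty in either direction. The estimated change is a 2.1-fold higher number from compound 3 to compound 4 (0.32 log units; beyond the scatter). Compound 4 is expected at 1800 nM, with an estimated range of 450 nM to 7000 nM.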

Compound 4, concentration for 50% growth inhibition: 5700 nM
Compound 4: middle estimate off by 3.2-fold (0.50 log units), on the low side; the range from low to high includes it.
By their numbers in this assay, from the lowest: compound 1; then compound 3; then compounds 2 and 4 (each within the scatter of the next).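

In this assay, within the data shown here, butyl is the first group at this place that has no ring, and it brings a 6.6-fold higher number from compound 3 to compound 4 (0.82 log units; beyond the scatter) and a 15-fold higher number from compound 1 to compound 4 (1.19 log units; beyond the scatter) when set against the two rings that gave the lower numbers. Set against the third ring, butyl gives a 1.3-fold higher number from compound 2 to compound 4 (0.11 log units; within the scatter) and so cannot be told apart from 4-methylphenyl, which means that an open chain and a ring bearing a methyl land at about the same level. Having a ring here is therefore not enough for a low number, as compound 2 shows, while among these four compounds the plain phenyl of compound 1 still gives the strongest inhibition of growth. No measurement at hand explains why butyl and 4-methylphenyl behave alike here.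

The compounds shown leave open whether a shorter chain such as ethyl or a longer chain such as hexyl would follow butyl, and whether an amine or a hydroxyl at the end of the chain would change the picture. They also leave open how a phenyl ring carrying chlorine or methoxy in place of the methyl would compare.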